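From fluoro to thiophen-2-yl: notes on compound 4

The source may report more compounds than this note shows. Statements on the series, on what has been measured and on what is new or still open speak of the compounds shown alone.

compound 1 `O=C(COc1ccccc1)Nc1cccc(C(=O)O)c1` gives > 30000 nM
compound 2 `O=C(COc1ccc(F)cc1)Nc1cccc(C(=O)O)c1` gives > 30000 nM
compound 3 `Cc1ccc(OCC(=O)Nc2cccc(C(N)=O)c2)cc1` gives > 30000 nM

In a functional assay on AGS cells (Homo sapiens) for inhibition, read by reporter gene assay (on this read-out lower numbers stand for stronger inhibition and higher numbers for weaker inhibition), compound 2 stands at > 30000 nM as a limit of the assay and not a number. For the measured compounds named here, the measured set as a whole offers only the limit of > 30000 nM in this assay, at which 3 of the 3 values shown sit, and no readable value so far.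

The change to follow leads to compound 4 `O=C(COc1ccc(-c2cccs2)cc1)Nc1cccc(C(=O)O)c1` and is counted as thiophen-2-yl in place of fluoro on an aromatic carbon with thiophen-2-yl in place of fluoro on an aromatic carbon.

Going by the values given here, one measured step bears on substitution at this place: a step that the two limits leave unreadable from compound 1 to compound 2 gives no size to carry over. Among the compounds with values here, compound 3 differs from compound 2 in more than one place and adds no step.

With no measured size to lean on, the direction rests on the structural change alone. A move toward stronger inhibition is the only outcome that could appear as a number in this assay and a second result at the limit remains about as likely. The expected step is an at least 2.5-fold lower number from compound 2 to compound 4 (0.39 log units; beyond the scatter) toward stronger inhibition, and this is a loose estimate. For compound 4 the estimated value is 12000 nM with an expected range from 3000 nM to 30000 nM in this assay.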

Compound 4, half-maximal inhibitory concentration: > 30000 nM
Compound 4: only a limit was reported (the forecaster's own chance of this, stated with the estimate: 45%); middle value at least 2.5-fold (0.39 log units) away from the limit.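

In this assay compound 4 gives > 30000 nM, a limit of the assay and not a number. The steps to compound 4 from compound 1 and compound 2 cannot be read, and neither thiophen-2-yl replacement gains a size. The compounds shown leave open whether any change to the shared core gives a readable value: the limit of > 30000 nM in this assay, at which 4 of the 4 values shown sit.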